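Thiourea in Place of Cyanoguanidine on a Pyridazinone Chain

The compounds below may be only part of what the source reports. "The series", "measured", "known", "first", "only" and "open" are said of these compounds alone.

Compound 2, `CC/N=C(/NC#N)NCCCn1nc(-c2ccccc2)ccc1=O`, stands highest of the three compounds measured in a functional assay on the whole organism with Rattus norvegicus as the target, at a dose of 100 mg/kg (on this read-out higher numbers stand for more inhibition at the one dose given (going by the name of the read-out) and lower numbers for less inhibition), where compound 2 gives 62.9%. For the measured compounds named here, its nearest neighbour is compound 1, `CC/N=C(/NC#N)NCCCn1nc(-c2ccccc2)cc(C)c1=O`, for which this assay gives 23.5%; the only single-point step recorded, a number 39.4 percentage points higher from compound 1 to compound 2 (beyond the scatter), arises from hydrogen in place of methyl on an aromatic carbon. Furthest away is compound 3, `C/N=C(/NC#N)NCCCCn1nc(N2CCN(C)CC2)ccc1=O`, which in this assay gives 7.9%; compound 3 differs from compound 2 in more than one place, so no step between them is set out.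

Compound 4, `C/N=C(\S)NCCCn1nc(-c2ccccc2)ccc1=O`, is the next compound to be tested. It differs from compound 2 by a group of 4 heavy atoms (2 carbon, 1 nitrogen, 1 sulfur; no ring) in place of a group of 7 heavy atoms (4 carbon, 3 nitrogen; no ring), on an amine nitrogen.

Going by the values given here, no measured step touches the amine nitrogen or the group that leaves it: the one step recorded, from compound 1 to compound 2, concerns an aromatic carbon elsewhere in the molecule, and compound 3 carries a different chain and a different ring substituent altogether. The expectation for compound 4 therefore rests on little more than the standing of compound 2. The author expects a modest fall, a number 17.9 percentage points lower from compound 2 to compound 4 (beyond the scatter), with a wide band of uncertainty. Compound 4 is estimated to give 45% in this assay, between 20% and 70%.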

Compound 4, a percentage reported as inhibition, in the whole organism at one dose (the size of the read-out at that dose, not a potency): 38.9%
Compound 4: the middle estimate sits 6.1 percentage points above what was measured, and the stated range covers the measured number.
By their numbers in this assay, from the lowest: compound 3; then compound 1; then compound 4; then compound 2.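

For the compounds shown here, the step of a number 24 percentage points lower from compound 2 to compound 4 (beyond the scatter) is the first reading at the amine nitrogen, and it shows that in this assay this position is not indifferent to what it carries: a group of 4 heavy atoms (2 carbon, 1 nitrogen, 1 sulfur; no ring) does not serve as a like-for-like stand-in for the group of 7 heavy atoms (4 carbon, 3 nitrogen; no ring). The change does not remove the read-out, since compound 4 still gives 38.9% at the one dose, so inhibition in the whole organism survives the loss of the triple bond counted in the group that leaves. Nothing at hand bears on why the number falls with this change.

The compounds shown leave open whether the fall goes with the sulfur atom or with the smaller group as a whole, a question that a version of the entering group with an oxygen atom in place of the sulfur, or with an ethyl group in place of its methyl, would address. They also leave open whether the same change on the amine nitrogen gives a step of similar size when the aromatic carbon carries a methyl, as in compound 1.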